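Swapping a sulfur-linked aryl for an oxygen-linked one

This account rests on a few compounds, and the source may have more. Where it says the series, first, only, none or still open, it means among the compounds named here.

Compound 1, `COc1ccc(Sc2nc3cc(N)cc(N)c3nc2-c2ccccc2)cc1`: in a functional assay on Hs-578T cells (Homo sapiens) for inhibition, read by sulforhodamine B assay, with a stated time of 48 h (on this read-out higher numbers stand for weaker inhibition of growth and lower numbers for stronger inhibition of growth), compound 1 gives < 100000 nM, a limit of the assay.
Compound 2, `Nc1cc(N)c2nc(-c3ccccc3)c(Sc3ccc(Cl)c(Cl)c3)nc2c1`: in this assay compound 2 gives < 100000 nM, likewise a limit.

Compound 2 thus stands only at a limit, not at a number; (the limit of < 100000 nM in this assay, at which 2 of the 2 values shown sit). The step that the two limits leave unreadable from compound 1 to compound 2 is accordingly of unreadable size. Compound 3, `Nc1cc(N)c2nc(-c3ccccc3)c(Oc3ccc(F)cc3)nc2c1`, differs from compound 2 by 4-fluorophenoxy in place of (3,4-dichlorophenyl)sulfanyl on an aromatic carbon. For the measured compounds named here, no measured step of readable size bears on this change, so no direction beyond the scatter can be set for it. Compound 3 is expected at 30000 nM, within 5000 nM to 100000 nM. That estimate amounts to an expected step that the limit leaves unreadable from compound 2 to compound 3.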

Compound 3, concentration for total growth inhibition: 53700 nM
The estimate for compound 3 lay 1.8-fold (0.25 log units) below the measured number; the measured number falls inside the stated range.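

No step to compound 3 can be read from compound 1 or compound 2, as both of these stand only at a limit: the limit of < 100000 nM in this assay, at which 2 of the 3 values shown sit.

Going by these compounds, whether 4-fluorophenoxy in place of (3,4-dichlorophenyl)sulfanyl strengthens or weakens inhibition of growth in this assay stays open.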